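From 4-fluorophenyl to 3,4,5-trimethoxyphenyl on a shared core

The compounds below may be only part of what the source reports. "The series", "measured", "known", "first", "only" and "open" are said of these compounds alone.

- compound 1 `Cn1cc(C2CC(c3ccc(F)cc3)=NN2C(=O)c2cccnc2)c2cc(Br)ccc21` gives 630 nM
- compound 2 `COc1ccc2c(c1)c(C1CC(c3ccccc3)=NN1C(=O)c1cccnc1)cn2C` gives 3590 nM
- compound 3 `COc1ccc2c(c1)c(C1CC(c3ccc(F)cc3)=NN1C(=O)c1ccc(OC)nc1)cn2C` gives 410 nM

These three compounds were tested in a functional assay on HeLa cells (Homo sapiens) for inhibition, read by MTT assay, with a stated time of 48 h (on this read-out higher numbers stand for weaker inhibition of growth and lower numbers for stronger inhibition of growth), and share one core. Compound 3 (410 nM) and compound 1 (630 nM) lie within the usual scatter of each other. Compound 2 (3590 nM) shows clearly weaker growth inhibition than compound 3, by a gap beyond the scatter, although those two differ in more than one place.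

Compound 4 `COc1ccc2c(c1)c(C1CC(c3cc(OC)c(OC)c(OC)c3)=NN1C(=O)c1ccc(OC)nc1)cn2C` keeps everything in compound 3 except one group: it has 3,4,5-trimethoxyphenyl in place of 4-fluorophenyl on a carbon with a double bond to nitrogen. Among the measured compounds shown here, no measured pair shows this change alone, so its size in this assay is uncertain. The expectation therefore starts from compound 3 (410 nM) and foresees no step beyond the scatter. The estimated step is a 1.1-fold higher number from compound 3 to compound 4 (0.04 log units; within the scatter) and could go either way. For compound 4 the expected value is 450 nM with an estimated range from 90 nM to 2500 nM on this measure.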

Compound 4, concentration for 50% growth inhibition: > 10000 nM
Compound 4: only a limit was reported; the forecaster's own chance of this, stated with the estimate: 3%; middle value at least 22-fold (1.34 log units) away from the limit.
By their numbers in this assay, from the lowest: compounds 3 and 1 (each within the scatter of the next); then compound 2. At a limit, above all of these: compound 4.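

Among the compounds shown here, replacing 4-fluorophenyl with 3,4,5-trimethoxyphenyl on the carbon with a double bond to nitrogen gives an at least 24-fold higher number from compound 3 to compound 4 (1.38 log units; beyond the scatter) in this assay, the first view of a change at this position on its own. The value of compound 4, > 10000 nM, is a limit of the assay and not a number. Growth inhibition at this position therefore depends strongly on which aromatic group is present, although this reading rests on a single pair and a single limit: the limit of > 10000 nM in this assay, at which 1 of the 4 values shown sits.

The compounds shown cannot separate the loss of the fluorine from the arrival of the three methoxy groups. As far as these compounds go, whether 4-methoxyphenyl or 4-aminophenyl at this position would retain growth inhibition also remains open.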